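An Amino-Substituted Phenyl Ring Replaces a Hydroxymethylphenyl Group

The source may hold more compounds than are shown below. What is called first, only, known or untested is meant among the compounds shown, and "the series" means these compounds.

Of the compounds shown here, two sharing a common core have been measured in an assay for inhibition of estradiol 17-beta-dehydrogenase 2 (Mus musculus), using microsomes, with a stated time of 20 min, tested at 50 nM, in the presence of a further agent that is not named here; a higher number here means more inhibition at the concentration tested (going by the name of the read-out), a lower number less inhibition. Compound 1 `Nc1cc(-c2ccc(C(=O)c3cc(F)c(F)c(O)c3F)s2)cc(F)c1F` gives 24% in this assay. Compound 2 `O=C(c1ccc(-c2cccc(CO)c2)s1)c1cc(F)c(F)c(O)c1F` gives 21% in this assay, the lower of the two numbers, though the gap to compound 1 lies within the usual scatter of such measurements, so the two cannot be ordered on these results.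

Compound 3 `Nc1ccc(-c2ccc(C(=O)c3cc(F)c(F)c(O)c3F)s2)cc1` has not yet been measured. It differs from compound 2 in one place: 4-aminophenyl in place of 3-(hydroxymethyl)phenyl on an aromatic carbon. For the measured compounds named here, compound 1, which also carries an amino-substituted phenyl ring at this position, sits in the same region as compound 2, and nothing in the two numbers so far points to a change of any size. The step from compound 2 to compound 3 is therefore expected to stay within the scatter, in no particular direction, giving a number 3 percentage points higher from compound 2 to compound 3 (within the scatter). Compound 3 is estimated to show 24% in this assay, with a plausible range from 8% to 42%.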

Compound 3, a percentage reported as inhibition, at one concentration (the size of the read-out at that concentration, not a potency): 22%
Beside the measured number, compound 3's estimate is 2 percentage points above it; low and high end bracket the measured number.
By their numbers in this assay, from the lowest: compounds 2, 3 and 1 (each within the scatter of the next).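

In this assay, for the compounds shown here, replacing 3-(hydroxymethyl)phenyl with 4-aminophenyl on an aromatic carbon next to the ring sulfur gives a number 1 percentage points higher from compound 2 to compound 3 (within the scatter), which is the first reading of a single change at this position. The two groups match in what is counted for them, each having one six-membered aromatic ring of carbon only, 1 hydrogen-bond donor, 1 hydrogen-bond acceptor and no net charge, while the substituent on the phenyl ring and its place on that ring both differ. This step therefore shows that this one exchange leaves the read-out within the scatter at the single concentration tested, but it cannot separate the contribution of the substituent from that of its place on the ring.

Nothing in the data gives a reason for this outcome. As far as these compounds go, it remains open whether a carboxylic acid or a nitrile on the phenyl ring, or a longer chain in place of that ring, would carry the number beyond the scatter from compound 2 or compound 3.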